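Swapping isopropyl for (dimethylcarbamoyl)methyl on an aromatic nitrogen

The source may report more compounds than this note shows. Statements on the series, on what has been measured and on what is new or still open speak of the compounds shown alone.

In a functional assay on KG-1 cells (Homo sapiens) for antiproliferative activity, read by CCK-8 assay, with a stated time of 72 h (on this read-out higher numbers stand for weaker inhibition and lower numbers for stronger inhibition), compound 2 `Cc1ccc(C(=O)Nc2cccc(C(F)(F)F)c2)cc1-c1ccc2c(-c3cnn(C(C)C)c3)n[nH]c2c1` gives 452 nM. Within the data shown here, the only other measured analogue, compound 1 `CCCn1cc(-c2n[nH]c3cc(-c4cc(C(=O)Nc5cccc(C(F)(F)F)c5)ccc4C)ccc23)cn1`, gives 358 nM, and these two values lie within the scatter of each other. Compound 3 `Cc1ccc(C(=O)Nc2cccc(C(F)(F)F)c2)cc1-c1ccc2c(-c3cnn(CC(=O)N(C)C)c3)n[nH]c2c1` has not yet been measured. It keeps the shared core of compound 2 and differs in one place, with (dimethylcarbamoyl)methyl in place of isopropyl on an aromatic nitrogen. Among the measured compounds shown here, only one measured step bears on this change, a 1.3-fold higher number from compound 1 to compound 2 (0.10 log units; within the scatter), which exchanged propyl for isopropyl on an aromatic nitrogen. For the measured compounds named here, that step is small, but it links two plain carbon chains, and no measured compound here carries a carbonyl in this group. It therefore offers only weak guidance for the larger replacement, and the data give no direction for it. A shift beyond the scatter is not expected, although the uncertainty is wide, and the estimate is a 1.1-fold lower number from compound 2 to compound 3 (0.05 log units; within the scatter). For compound 3 the expected value is 400 nM, with an estimated range from 150 nM to 1100 nM.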

Compound 3, half-maximal inhibitory concentration: 441 nM
Beside the measured number, compound 3's estimate is 1.1-fold (0.04 log units) below it; the measured number falls inside the stated range.
By their numbers in this assay, from the lowest: compounds 1, 3 and 2 (each within the scatter of the next).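

In this assay, replacing isopropyl with (dimethylcarbamoyl)methyl on the aromatic nitrogen gives a 1.0-fold lower number from compound 2 to compound 3 (0.01 log units; within the scatter), so this position accepts a group of 6 heavy atoms with a carbonyl and 1 hydrogen-bond acceptor with no reading beyond the scatter. Measured against the propyl compound, the same group gives a 1.2-fold higher number from compound 1 to compound 3 (0.09 log units; within the scatter), which places all three groups on this nitrogen within the scatter of one another. The earlier pair compared only plain carbon chains, whereas compound 3 brings a carbonyl into the group, and this read-out does not tell it apart from those chains. No evidence is available to account for this result.

As far as these compounds go, whether an amine, a carboxylic acid, a longer chain or a ring on this nitrogen would move the number beyond the scatter remains open. All three compounds appear only in this assay and with the rest of the shared core unchanged, so how far this tolerance extends to another read-out or another core also stays unanswered.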